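Ethyl Ester of Compound 2: Expected Cytotoxicity

A few compounds are considered here, and "the series" means these few. Any claim that something is new, unique, unknown or untested is made for them only; others in the source may bear on it.

Going by the values given here, compound 2 `COc1ccc(/C=C/C(=O)O)c(OC(=O)c2nc(C)c(C)nc2C)c1` stands lowest of the two numbers measured so far. In a functional assay on EA.hy 926 cells (Homo sapiens) for cytotoxicity, read by MTT assay, with stated times of 24 h and 12 h, tested at 50 uM (on this read-out higher numbers stand for a stronger effect at the one concentration tested and lower numbers for a weaker effect), compound 2 gives 31.6%. Its nearest neighbour is compound 1 `Cc1nc(C)c(C(=O)Oc2ccccc2/C=C/C(=O)O)nc1C`, which in this assay gives 64.9%. Among the compounds with values here, the only measured step in the set, a number 33.3 percentage points lower from compound 1 to compound 2 (beyond the scatter), concerns methoxy in place of hydrogen on an aromatic carbon and is large.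

Compound 3 `CCOC(=O)/C=C/c1ccc(OC)cc1OC(=O)c1nc(C)c(C)nc1C` differs from compound 2 by ethyl in place of hydrogen on an oxygen next to a carbonyl group. Cut one bond further out, the change reads carboxy to ethoxycarbonyl. Within the data shown here, no measured step touches this part of the molecule: the one step available, a number 33.3 percentage points lower from compound 1 to compound 2 (beyond the scatter), sits at a different position and gives no guide to either direction or size here. The expectation for compound 3 in this assay therefore rests on compound 2 alone and must carry a wide range.

For compound 3 in this assay the estimate is 36%, with a range from 15% to 60%. The step this estimate implies, a number 4.4 percentage points higher from compound 2 to compound 3 (within the scatter), is expected to stay within the scatter, though with little confidence in either direction.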

Compound 3, a percentage reported as activity, at one concentration (the size of the read-out at that concentration, not a potency): 20.7%
For compound 3 the middle estimate is 15.3 percentage points above the measured one; the measured number falls inside the stated range.
By their numbers in this assay, from the lowest: compound 3; then compound 2; then compound 1.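

In this assay, going by these compounds alone, this is the first measured change at the carboxy end of the series: carboxy to ethoxycarbonyl, with ethyl in place of hydrogen on an oxygen next to a carbonyl group, gives a number 10.9 percentage points lower from compound 2 to compound 3 (beyond the scatter), a modest step. The read-out at this position therefore responds to the change, and it goes down rather than staying flat, which the step at the aromatic carbon, a number 33.3 percentage points lower from compound 1 to compound 2 (beyond the scatter), could not show because it sits elsewhere on the molecule. Both listed steps lower the number, but they concern different places and different changes, so they form no shared trend, and nothing available speaks to why the ethoxycarbonyl compound reads lower.

The compounds shown do not separate the effect of the ethyl group itself from that of replacing the hydrogen, a question that a methoxycarbonyl group, a longer chain such as butoxycarbonyl, or an amide at the same place would address. Going by these compounds, it also remains open whether the carboxy to ethoxycarbonyl change gives a similar step on the core of compound 1, which carries hydrogen in place of methoxy.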